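Acylation of the ring amine in compound 2

A few compounds are considered here, and "the series" means these few. Any claim that something is new, unique, unknown or untested is made for them only; others in the source may bear on it.

Compound 1 `Cc1c2c(n3c1CCCN[C@@H](C)[C@H](C)Nc1cc-3ccc1C(N)=O)CC(C)(C)CC2=O`: 61 nM
Compound 2 `Cc1c2c(n3c1CCNC[C@@H](C)[C@H](C)Nc1cc-3ccc1C(N)=O)CC(C)(C)CC2=O`: 40 nM
Compound 3 `CC(=O)N1CCCc2c(C)c3c(n2-c2ccc(C(N)=O)c(c2)N[C@@H](C)[C@@H]1C)CC(C)(C)CC3=O`: 29 nM

All three values come from a functional assay on U-87MG ATCC cells (Homo sapiens) for antiproliferative activity; a higher number here means a weaker inhibitor, a lower number a stronger inhibitor. Compound 2 lies within the scatter of both compound 1 and compound 3. Compound 4 `COCCC(=O)N1CCc2c(C)c3c(n2-c2ccc(C(N)=O)c(c2)N[C@@H](C)[C@H](C)C1)CC(C)(C)CC3=O` differs from compound 2 as follows: (2-methoxyethyl)carbonyl in place of hydrogen on an amine nitrogen in a ring. This places (2-methoxyethyl)carbonyl in place of hydrogen on an amine nitrogen in a ring.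

For the measured compounds named here, the only measured step of this kind puts acetyl in place of hydrogen on an amine nitrogen in a ring: a 2.1-fold lower number from compound 1 to compound 3 (0.32 log units; beyond the scatter). It is a single, modest precedent, with a different entering group, so only a small move to a lower number in this assay is expected, possibly within the scatter. The expected change is a 1.6-fold lower number from compound 2 to compound 4 (0.20 log units; within the scatter). The estimate for compound 4 is 25 nM, with an expected range of 10 nM to 60 nM.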

Compound 4, half-maximal inhibitory concentration: 54 nM
For compound 4 the middle estimate is 2.2-fold (0.33 log units) below the measured one; low and high end bracket the measured number.
By their numbers in this assay, from the lowest: compounds 3, 2, 4 and 1 (each within the scatter of the next, the first and the last beyond it).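

In this assay the acylation gives a 1.4-fold higher number from compound 2 to compound 4 (0.13 log units; within the scatter) and so (2-methoxyethyl)carbonyl on the amine nitrogen in the ring cannot be told apart from hydrogen there. The acetyl precedent, a 2.1-fold lower number from compound 1 to compound 3 (0.32 log units; beyond the scatter) stands on a different parent, and on compound 2 this acylation brings no readable gain. Nothing measured bears on the reason for this result.

Open, as far as these compounds go, is whether acetyl on compound 2 would behave as (2-methoxyethyl)carbonyl does, and whether a longer chain or a carboxylic acid on this nitrogen would move the number beyond the scatter.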